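Sulfonamide nitrogen aryl swap in the chlorobenzyl amide series

The source may hold more compounds than are shown below. What is called first, only, known or untested is meant among the compounds shown, and "the series" means these compounds.

Compound 1 `CCc1ccccc1N(CC(=O)NCc1cccc(Cl)c1)S(=O)(=O)c1ccc(C)cc1`: 251 nM in an assay on CHO cells for displacement of a labelled ligand from prostaglandin E2 receptor EP1 subtype (Homo sapiens); a higher number here means a weaker inhibitor, a lower number a stronger inhibitor.
Compound 2 `CCc1ccccc1N(CC(=O)NCc1ccc(Cl)cc1)S(=O)(=O)c1ccc(C)cc1`: 10 nM in this assay.
Compound 3 `Cc1ccc(S(=O)(=O)N(CC(=O)NCc2ccc(Cl)cc2)c2cccnc2)cc1`: < 1000 nM in this assay, which is a limit of the assay and not a number.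

Within the data shown here, compound 2 has the lowest of the two readable numbers in this assay; the nearest is compound 1, and the step of a 25-fold lower number from compound 1 to compound 2 (1.40 log units; beyond the scatter) is the only sized step in the set. For compound 3 only the limit of < 1000 nM in this assay, at which 1 of the 3 values shown sits, exists, so the step that the limit leaves unreadable from compound 2 to compound 3 cannot be sized. Compound 4 `Cc1ccc(S(=O)(=O)N(CC(=O)NCc2ccc(Cl)cc2)c2ncccc2C)cc1` differs from compound 2 as follows: 3-methylpyridin-2-yl in place of 2-ethylphenyl on a sulfonamide nitrogen. Among the measured compounds shown here, the one measured change at the sulfonamide nitrogen, from compound 2 to compound 3, gives no readable size, so no measured step bears on this change with a usable magnitude. A moderate rise in the number is expected, a 6.0-fold higher number from compound 2 to compound 4 (0.78 log units; beyond the scatter), with wide uncertainty. For compound 4 the expected value in this assay is 60 nM, estimated between 12 nM and 350 nM.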

Compound 4, inhibition constant: 794 nM
For compound 4 the middle estimate is 13-fold (1.12 log units) below the measured one; the measured number lies above the stated range.
By their numbers in this assay, from the lowest: compound 2; then compound 1; then compound 4.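

The sulfonamide nitrogen now has its first sized step: in this assay, 3-methylpyridin-2-yl in place of 2-ethylphenyl gives a 79-fold higher number from compound 2 to compound 4 (1.90 log units; beyond the scatter). The aryl group at this position therefore moves the number strongly, as the chlorophenyl swap did at the amide end. The steps involving compound 3 cannot be read, as compound 3 carries a limit and not a number: the limit of < 1000 nM in this assay, at which 1 of the 4 values shown sits.

This swap alters the ring hetero atom and the alkyl group at once, so their shares remain unseparated. A 2-methylphenyl or 3-ethylpyridin-2-yl group on this nitrogen would divide them.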